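Moving the Chlorine on the Carboxyphenyl Ring

The source may report more compounds than this note shows. Statements on the series, on what has been measured and on what is new or still open speak of the compounds shown alone.

Measured so far:
compound 1: `COc1cc(C(=O)O)ccc1OCCCCOc1ccc(C(=O)CC(C)C)c(O)c1C` — 85.7%
compound 2: `Cc1c(OCCCCOc2ccc(C(=O)O)cc2Cl)ccc(C(=O)CC(C)C)c1O` — 99.5%

Of the compounds shown here, two have been measured in an assay on HEK293 cells for positive allosteric modulation of metabotropic glutamate receptor 2 (Rattus norvegicus), read by thallium flux, with a stated time of 2.5 min; a lower number here means a smaller maximal response, a higher number a larger maximal response. Compound 1 `COc1cc(C(=O)O)ccc1OCCCCOc1ccc(C(=O)CC(C)C)c(O)c1C` gives 85.7%, and compound 2 `Cc1c(OCCCCOc2ccc(C(=O)O)cc2Cl)ccc(C(=O)CC(C)C)c1O` gives 99.5%. Going by the values given here, compound 2 stands highest of the two numbers, and the only measured step, a number 13.8 percentage points higher from compound 1 to compound 2 (beyond the scatter), is modest yet beyond the scatter.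

Compound 3 `Cc1c(OCCCCOc2ccc(C(=O)O)c(Cl)c2)ccc(C(=O)CC(C)C)c1O` has not yet been measured. 4-carboxy-3-chlorophenyl in place of 4-carboxy-2-chlorophenyl on an oxygen on a saturated carbon The two compounds hold the same atoms, joined differently: the chlorine stays on the same ring but changes place. Among the compounds with values here, only one measured step exists, a number 13.8 percentage points higher from compound 1 to compound 2 (beyond the scatter), and it concerns chloro in place of methoxy, not the place of a chlorine that is already there, so it bears on this change only loosely. Within the data shown here, no measured pair moves a substituent around that ring.

Compound 2 sits at the top of the two numbers with 99.5%, so a shift from it has more room to fall than to rise. For compound 3 the expected step in this assay is a number 7.5 percentage points lower from compound 2 to compound 3 (within the scatter), which is none beyond the scatter. Compound 3 is therefore estimated at 92%, with a range from 75% to 106%.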

Compound 3, largest response reached (reported as percent of maximum), in percent of the reference or control that the assay uses: 80.5%
Compound 3: middle estimate off by 11.5 percentage points, on the high side; low and high end bracket the measured number.
By their numbers in this assay, from the lowest: compounds 3 and 1 (each within the scatter of the next); then compound 2.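

In this assay the place of the chlorine proves to matter on its own: with the same atoms joined differently, 4-carboxy-3-chlorophenyl in place of 4-carboxy-2-chlorophenyl on the oxygen gives a number 19 percentage points lower from compound 2 to compound 3 (beyond the scatter) for the largest response reached. The earlier step, a number 13.8 percentage points higher from compound 1 to compound 2 (beyond the scatter), exchanged one group for another, whereas this one moves a substituent around the ring and runs the opposite way, so among these compounds the higher maximal response of compound 2 belongs to chlorine in that particular place and not to the presence of chlorine on the ring as such. Nothing available on these compounds accounts for the size or direction of this shift.

The compounds shown leave open whether a methoxy group would answer the same move as the chlorine does, and whether a fluorine or a methyl group in the place of that chlorine would hold the response of compound 2 or lose it. They also leave open how a longer chain between the two oxygens, or an amide in place of the carboxylic acid, would alter the picture.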